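Methyl on the amide-type nitrogen of compound 2

A few compounds are considered here, and "the series" means these few. Any claim that something is new, unique, unknown or untested is made for them only; others in the source may bear on it.

Measured so far in a functional assay on the whole organism for agonist activity, with Mus musculus as the target; a lower number here means that less compound is needed, a higher number that more compound is needed for the effect:
- compound 1 `CC(=O)NCC#CCn1cncc1C`: > 100 mg/kg
- compound 2 `COC(=O)NCC#CCn1cncc1C`: > 100 mg/kg

In this assay compound 2 gives > 100 mg/kg, which is a limit of the assay and not a number. Compound 1 also gives only a limit, so neither compound has yet returned a numerical dose. The evidence so far amounts to the limit of > 100 mg/kg in this assay, at which 2 of the 2 values shown sit.

Compound 3 `COC(=O)N(C)CC#CCn1cncc1C` has methyl in place of hydrogen on an amide-type nitrogen. Among the compounds with values here, no measured step covers a change at that nitrogen. Within the data shown here, the only measured step is methoxy in place of methyl on a carbonyl carbon, a step that the two limits leave unreadable from compound 1 to compound 2. It offers no size or direction to carry over. The expectation therefore rests on the shared limit, and a dose within reach of the assay would be a departure from both measured compounds. Compound 3 is expected to end at the same limit, most likely reported without a number. The expected change is a step that the limit leaves unreadable from compound 2 to compound 3, with no direction favoured by the data. For compound 3 the estimated dose is 150 mg/kg, with an expected range of 60 mg/kg to 400 mg/kg.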

Compound 3, dose for half-maximal effect: 4.5 mg/kg
The estimate for compound 3 lay 33-fold (1.52 log units) above the measured number, and the stated range ends above it.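

In this assay, within the data shown here, methyl in place of hydrogen on the amide-type nitrogen, whose other neighbours are a carbonyl carbon and a saturated chain carbon, gives an at least 22-fold lower number from compound 2 to compound 3 (1.34 log units; beyond the scatter) and brings the series into a readable dose range for the first time. The amide-type nitrogen is therefore a position where the read-out responds strongly to a single added carbon, whereas the change on the carbonyl carbon shows nothing, since the step between two limits cannot be read. Compound 3 is the only compound shown with a numerical dose, and the other values are limits of the assay, not numbers: the limit of > 100 mg/kg in this assay, at which 2 of the 3 values shown sit.

It remains open whether this response is specific to methyl or would also appear with ethyl, a longer chain or a cyclopropyl group on the same nitrogen, and the compounds shown give no measured property that could explain it. On these data alone, it is also open whether methyl on the nitrogen of compound 1, which carries methyl rather than methoxy on the carbonyl carbon, would give a similar step, so this single step does not yet establish a pattern.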